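Chloro added to the aryl ring of compound 1

The compounds below may be only part of what the source reports. "The series", "measured", "known", "first", "only" and "open" are said of these compounds alone.

Working notes on a short series of aminooxazolines tested in a functional assay on HEK293 cells for agonist activity at trace amine-associated receptor 1 (Homo sapiens), read by cAMP accumulation, with a stated time of 30 min; on this read-out higher numbers stand for an effect only at larger amounts of compound and lower numbers for an effect already at smaller amounts. Compound 1 `Cc1ccccc1[C@H]1COC(N)=N1` gives 67 nM. Compound 2 `NC1=N[C@@H](CCOc2ccccc2)CO1` gives 9 nM, a lower number than compound 1 by more than the scatter. Compound 3 `NC1=N[C@@H](COCc2ccccc2)CO1` gives 360 nM, a higher number than compound 1 by more than the scatter. Compound 1 thus stands second highest of the three numbers, nearest to compound 3. Compound 4 `Cc1cc(Cl)ccc1[C@H]1COC(N)=N1` is not yet measured; its change from compound 1 is chloro in place of hydrogen on an aromatic carbon, on an aromatic carbon meta to a methyl group and para to the group of 6 heavy atoms. Among the measured compounds shown here, no measured step of this kind is known here. A step from compound 1 to compound 4 of a 2.2-fold lower number from compound 1 to compound 4 (0.35 log units; beyond the scatter) is expected, in the direction of a smaller number. For compound 4 the estimate is 30 nM, within 8 nM to 120 nM.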

Compound 4, half-maximal effective concentration: 11 nM
For compound 4 the middle estimate is 2.7-fold (0.44 log units) above the measured one, within the range that was stated.
By their numbers in this assay, from the lowest: compounds 2 and 4 (each within the scatter of the next); then compound 1; then compound 3.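

In this assay, among the compounds shown here, chloro in place of hydrogen on the aromatic carbon para to the group of 6 heavy atoms and meta to the methyl group gives a 6.1-fold lower number from compound 1 to compound 4 (0.78 log units; beyond the scatter), the first measured step on this ring, and it lies beyond the scatter. This position therefore accepts chloro, and the number falls with it. Nothing available here accounts for the size of the step.

Going by these compounds, whether bromo, methoxy or an amine on this carbon gives a similar step remains open. Also open, on these data alone, is whether chloro changes the numbers of compound 2 and compound 3 in the same direction.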